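The compounds below may be only part of what the source reports. "The series", "measured", "known", "first", "only" and "open" are said of these compounds alone.

Measured so far:
compound 1, `CNc1nc(C)c(C(=O)N/N=C/c2ccccc2C(F)(F)F)s1`: > 100 ug/mL
compound 2, `CN(C(=O)NC(=O)c1cccc(C(F)(F)F)c1)c1nc(C(F)(F)F)c(C(=O)N/N=C/c2ccc(C(F)(F)F)cc2)s1`: 7.71 ug/mL
compound 3, `CN(C(=O)NC(=O)c1c(Cl)cccc1Cl)c1nc(C(F)(F)F)c(C(=O)N/N=C/c2ccccc2C(F)(F)F)s1`: 8.95 ug/mL

In a functional assay on HepG2 cells (Homo sapiens) for inhibition, read by MTT assay, with a stated time of 72 h (a lower number here means a stronger inhibitor, a higher number a weaker inhibitor), compound 1 gives > 100 ug/mL. On these data alone, that is a limit of the assay, not a number, so compound 1 stands at the limit of > 100 ug/mL in this assay, at which 1 of the 3 values shown sits, and its true position beyond that point is unknown. Compound 2 gives 7.71 ug/mL in this assay. Compound 3 gives 8.95 ug/mL in this assay; compound 2 and compound 3 lie within the scatter of each other, so no order is read between them. Among the compounds with values here, both carry a trifluoromethyl on the shared core together with an acylurea and differ from compound 1 in several places at once, so no single step between measured compounds can be drawn.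

Compound 4, `CNc1nc(C(F)(F)F)c(C(=O)N/N=C/c2ccccc2C(F)(F)F)s1`, differs from compound 1 by trifluoromethyl in place of methyl on an aromatic carbon, with nothing else changed. Compound 2 and compound 3 show that trifluoromethyl on the core is compatible with measurable inhibition, but their other changes are not separated from it. A step of modest size toward stronger inhibition is expected in this assay, possibly none beyond the scatter, as an at least 1.2-fold lower number from compound 1 to compound 4 (0.09 log units; that floor lies within the scatter). Compound 4 is estimated at 80 ug/mL, ranging from 30 ug/mL to 200 ug/mL, with a fair chance that only a limit is reported again.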

Compound 4, half-maximal inhibitory concentration: > 100 ug/mL
Compound 4: no number, only a limit (the forecaster's own chance of this, stated with the estimate: 55%); middle value at least 1.2-fold (0.09 log units) away from the limit.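

In this assay compound 4 gives > 100 ug/mL, a limit of the assay and not a number. Compound 1 also stands at a limit, so no step can be read between compound 1 and compound 4: the limit of > 100 ug/mL in this assay, at which 2 of the 4 values shown sit.

The compounds shown leave open whether trifluoromethyl in place of methyl on an aromatic carbon changes inhibition at all.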